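The source may hold more compounds than are shown below. What is called first, only, known or untested is meant among the compounds shown, and "the series" means these compounds.

Measured compounds:
- Compound 1, `O=C(Nc1ccc2nc(NC(=O)C3CC3)sc2c1)c1c(Cl)cccc1Cl`: 0.013 ug/mL
- Compound 2, `CC(C)COC(=O)Nc1nc2ccc(NC(=O)c3c(Cl)cccc3Cl)cc2s1`: 0.0035 ug/mL

In a functional assay on WI-38 VA13 cells (Homo sapiens) for cytotoxicity (on this read-out lower numbers stand for an effect already at smaller amounts and higher numbers for an effect only at larger amounts of compound), compound 2 gives the lowest of the two numbers, and compound 1 sits a single step away: a 3.7-fold lower number from compound 1 to compound 2 (0.57 log units; beyond the scatter). Compound 3, `COc1cccc(Nc2nc3ccc(NC(=O)c4c(Cl)cccc4Cl)cc3s2)c1`, has not yet been measured in this assay. It differs from compound 2 in one place: 3-methoxyphenyl in place of isobutoxycarbonyl on a nitrogen on an aromatic ring. Within the data shown here, the only measured step exchanges one group on a carbonyl carbon for another while keeping the carbonyl itself; here the whole isobutoxycarbonyl leaves and an aromatic ring enters on the nitrogen on an aromatic ring, so that step bears on it only loosely. Among the measured compounds shown here, with no closely comparable step, no direction beyond the scatter is expected, and a wide range is appropriate. The estimate for compound 3 is therefore 0.006 ug/mL, ranging from 0.001 ug/mL to 0.04 ug/mL. That estimated step from compound 2 is a 1.7-fold higher number from compound 2 to compound 3 (0.23 log units; within the scatter).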

Compound 3, half-maximal effective concentration: > 7.2 ug/mL
Compound 3: no number, only a limit (the forecaster's own chance of this, stated with the estimate: 5%); at least 1200-fold (3.07 log units) between middle value and limit.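

On the nitrogen on an aromatic ring, the choice of group turns out to matter far more than the earlier swap on the carbonyl carbon suggested: in this assay, 3-methoxyphenyl in place of isobutoxycarbonyl gives an at least 2000-fold higher number from compound 2 to compound 3 (3.31 log units; beyond the scatter). The same group in place of cyclopropylcarbonyl gives an at least 550-fold higher number from compound 1 to compound 3 (2.74 log units; beyond the scatter), so the large rise appears against both compounds that carry a carbonyl on this nitrogen. The entry for compound 3 is a limit and not a number, so both steps are minimum sizes: the limit of > 7.2 ug/mL in this assay, at which 1 of the 3 values shown sits.

As far as these compounds go, whether the rise comes from losing the carbonyl or from gaining the aromatic ring stays open, as the two changes arrive together in one step. A benzoyl group on this nitrogen, with both a carbonyl and an aromatic ring, or a plain ethyl chain, with neither, would separate them.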